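From propyl to 4-methylphenyl on the shared core

A few compounds are considered here, and "the series" means these few. Any claim that something is new, unique, unknown or untested is made for them only; others in the source may bear on it.

- compound 1 `CCCn1ccnc1-c1cc(OC)c(OC)c(OC)c1`: > 100000 nM (a limit)
- compound 2 `COc1cc(-c2nccn2S(=O)(=O)c2ccc(C)cc2)cc(OC)c1OC`: > 100000 nM (a limit)
- compound 3 `COc1cc(-c2nccn2-c2ccc3sccc3c2)cc(OC)c1OC`: 3300 nM

All three values come from a functional assay on HCT-15 cells (Homo sapiens) for antiproliferative activity, read by MTT assay, with a stated time of 72 h; a lower number here means a stronger inhibitor, a higher number a weaker inhibitor. Compound 1 stands at the limit of > 100000 nM in this assay, at which 2 of the 3 values shown sit. That entry is a limit and not a number, so it gives no fixed starting point. Compound 2 sits at the same limit. Only compound 3 gives a number.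

Compound 4 `COc1cc(-c2nccn2-c2ccc(C)cc2)cc(OC)c1OC` has not yet been measured. It has 4-methylphenyl in place of propyl on an aromatic nitrogen of the shared core (4-methylphenyl in place of propyl on an aromatic nitrogen). Within the data shown here, no measured step covers this change. The expectation in this assay is a move to a lower number, beyond the scatter. It rests on compound 3 at 3300 nM, which also carries an aromatic group on that nitrogen. Among the measured compounds shown here, with only this one comparison, the expectation is loose, and a result at the limit remains possible. The expected step is an at least 8.3-fold lower number from compound 1 to compound 4 (0.92 log units; beyond the scatter). For compound 4 the estimated value is 12000 nM, with an expected range of 2500 nM to 70000 nM.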

Compound 4, half-maximal inhibitory concentration: 800 nM
Compound 4: the middle estimate sits 15-fold (1.18 log units) above what was measured, outside the stated range (below it).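

In this assay, 4-methylphenyl in place of propyl on the aromatic nitrogen gives an at least 120-fold lower number from compound 1 to compound 4 (2.09 log units; beyond the scatter) and so brings this position from a limit to a number. Compound 3 also carries an aromatic group on that nitrogen and stands at 3300 nM in this assay, which makes two aromatic groups at this position that give numbers. The size of the step is only a lower bound, because the entry for compound 1 is a limit: the limit of > 100000 nM in this assay, at which 2 of the 4 values shown sit.

Open, from the compounds shown here alone, is whether the carbon-only aromatic ring itself matters, or whether a benzyl group or a longer chain on the same nitrogen would also give a number. Also open, going by these compounds, is how an amine or a carboxylic acid in place of the methyl of 4-methylphenyl would read.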